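Methoxy Added to the Phenylethenyl Carbonyl Arm

The source may hold more compounds than are shown below. What is called first, only, known or untested is meant among the compounds shown, and "the series" means these compounds.

Of the compounds shown here, three have so far been tested in an ADME assay on HEK293 cells (Homo sapiens) for antiproliferative activity, read by MTT assay, with a stated time of 24 h; a lower number here means a stronger inhibitor, a higher number a weaker inhibitor. Compound 1 `COc1ccc(-c2cc(C(=O)/C=C/c3ccccc3)nc3cc(-c4ccccc4)nn23)cc1OC` gives 64100 nM, the higher of the two numbers that were obtained. Compound 3 `COc1ccc(-c2cc(/C=C/C(=O)c3cc(OC)c(OC)c(OC)c3)nc3cc(-c4ccccc4)nn23)cc1OC` gives 35000 nM, a gap from compound 1 that lies within the scatter, so the two cannot be ranked against each other. For compound 2 `COc1cc(C(=O)/C=C/c2cc(-c3cc(OC)c(OC)c(OC)c3)n3nc(-c4ccccc4)cc3n2)cc(OC)c1OC` the assay reports only a limit, >= 100000 nM. Among the compounds with values here, the one step between neighbours that differ in a single place is an at least 2.8-fold lower number from compound 2 to compound 3 (0.45 log units; beyond the scatter), brought about by hydrogen in place of methoxy on an aromatic carbon.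

Compound 4 `COc1ccc(/C=C/C(=O)c2cc(-c3ccc(OC)c(OC)c3)n3nc(-c4ccccc4)cc3n2)cc1` has not been measured. It differs from compound 1 by methoxy in place of hydrogen on an aromatic carbon. Within the data shown here, that is the reverse kind of change to the one step on record, which lowered the number when a methoxy was removed; the same reading suggests that adding one should raise the number, with only this single step to go on. Compound 4 is therefore expected to give about 100000 nM, between 45000 nM and 220000 nM. The expected step is a 1.6-fold higher number from compound 1 to compound 4 (0.19 log units; within the scatter), which would bring the value to the limit of >= 100000 nM in this assay, at which 1 of the 3 values shown sits.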

Compound 4, half-maximal inhibitory concentration: 50700 nM
Compound 4: the middle estimate sits 2.0-fold (0.29 log units) above what was measured; the measured number falls inside the stated range.
By their numbers in this assay, from the lowest: compounds 3, 4 and 1 (each within the scatter of the next). At a limit, above all of these: compound 2.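

In this assay, going from 2-phenylethenyl to 2-(4-methoxyphenyl)ethenyl gives a 1.3-fold lower number from compound 1 to compound 4 (0.10 log units; within the scatter), so a methoxy on this ring, para to a large group, leaves the number within the scatter. Within the data shown here, the earlier compounds offered only one step of this kind, and it lay beyond the scatter. The new step shows that the exchange of hydrogen and methoxy does not carry the same size from one core to the other: the same change on two cores in this assay, an at least 2.8-fold lower number (0.45 log units; beyond the scatter) from compound 2 to compound 3 and a 1.3-fold higher number (0.10 log units; within the scatter) from compound 4 to compound 1, at least 3.6-fold (0.55 log units) apart, beyond the scatter of two such steps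

The compounds shown leave open whether the gap in these steps follows from the core or from the ring that carries the methoxy. They also leave open whether a hydroxyl, a fluorine or an amine in the same place would give a step beyond the scatter.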